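Azetidine in place of methylamino on a shared quinoline-type core

A few compounds are considered here, and "the series" means these few. Any claim that something is new, unique, unknown or untested is made for them only; others in the source may bear on it.

Three compounds share a core bearing a propyl or cyclohexyl group and an amide-linked cinnamoyl side chain. Compound 1 `CCCc1cc(NC)c2cc(NC(=O)/C=C/c3ccc(C(F)(F)F)cc3)ccc2n1` gives 150 nM in a functional assay on HEK293 cells for activation of melanin-concentrating hormone receptor 1 (Homo sapiens), read by inositol phosphate accumulation; a higher number here means that more compound is needed for the effect, a lower number that less compound is needed. Compound 2 `CCCc1cc(N)c2cc(NC(=O)/C=C/c3ccc(I)cc3)ccc2n1` gives 280 nM in this assay, and compound 3 `Nc1cc(C2CCCCC2)nc2ccc(NC(=O)/C=C/c3ccc(C(F)(F)F)cc3)cc12` gives 96 nM in this assay. The three numbers sit close together: compound 1 is nearest to compound 3 and furthest from compound 2, yet both of those gaps fall within the usual scatter, so no ranking among them can be claimed.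

Compound 4 `CCCc1cc(N2CCC2)c2cc(NC(=O)/C=C/c3ccc(C(F)(F)F)cc3)ccc2n1` has not yet been measured. It differs from compound 1 in one place: azetidin-1-yl in place of methylamino on an aromatic carbon. For the measured compounds named here, no measured pair shows this change, so the expectation rests on the closeness of the three numbers alone. The step from compound 1 to compound 4 is expected to be small, a 1.7-fold higher number from compound 1 to compound 4 (0.22 log units; within the scatter), leaning toward more compound being needed, but not clearly beyond the scatter. Compound 4 is therefore estimated at 250 nM in this assay, within a range from 80 nM to 800 nM.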

Compound 4, half-maximal effective concentration: 2500 nM
The estimate for compound 4 lay 10-fold (1.00 log units) below the measured number; measured number above the stated range.
By their numbers in this assay, from the lowest: compounds 3, 1 and 2 (each within the scatter of the next, the first and the last beyond it); then compound 4.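

At this position, opposite the ring nitrogen, swapping one small nitrogen group for another is not a neutral change: in this assay azetidin-1-yl in place of methylamino gives a 17-fold higher number from compound 1 to compound 4 (1.22 log units; beyond the scatter) and this is the first step shown at this position. The change removes the hydrogen-bond donor of methylamino, adds two heavy atoms and closes a four-membered ring, all at once, so this single pair cannot tell these differences apart. No measurement shown here accounts for the size of this step.

It remains open whether the step follows the lost hydrogen or the ring, since the compounds shown include neither a dimethylamino group, which has no such hydrogen and no ring, nor a pyrrolidine ring. Also open, going by these compounds, is whether the same step would appear with cyclohexyl in place of propyl.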